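The compounds below may be only part of what the source reports. "The series", "measured", "known", "first", "only" and "open" are said of these compounds alone.

Compound 1 `C[n+]1ccn(CCCC#N)c1/C=N/O` is the starting point. In a physicochemical assay for lipophilicity (on this read-out lower numbers stand for lower lipophilicity and higher numbers for higher lipophilicity), compound 1 gives < -3, which is a limit of the measurement and not a number, as the limit of < -3 in this assay, at which 1 of the 3 values shown sits, shows. Two related compounds have numbers: compound 2 `COC(=O)CCCCCn1cc[n+](C)c1/C=N/O` gives -2.21 in this assay, and compound 3 `C[n+]1ccn(CCCCOC(=O)c2ccccc2O)c1/C=N/O` gives -0.56.

The change to compound 4 `C[n+]1ccn(COCCCBr)c1/C=N/O` is 3-bromopropoxy in place of 2-cyanoethyl on a saturated chain carbon bound to an aromatic nitrogen. Within the data shown here, only one measured step bears on it: going a number at least 0.79 log units higher from compound 1 to compound 2 (beyond the scatter), a change that also removes the nitrile from a chain on the same aromatic nitrogen of the shared core. Among the measured compounds shown here, that step is the sole guide, and it points upward, so the move to compound 4 is expected to lift the read-out too, though with wide uncertainty since compound 1 stands only at a limit.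

The expected step is a number at least 1.00 log units higher from compound 1 to compound 4 (beyond the scatter). Compound 4 is therefore estimated at -2 in this assay, most likely between -2.9 and -1.1.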

Compound 4, distribution coefficient: -1.76
Estimate against measurement, compound 4: 0.24 log units below; the range from low to high includes it.
By their numbers in this assay, from the lowest: compound 2; then compound 4; then compound 3. At a limit, below all of these: compound 1.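

In this assay, putting 3-bromopropoxy in place of 2-cyanoethyl on a saturated chain carbon bound to an aromatic nitrogen gives a number at least 1.24 log units higher from compound 1 to compound 4 (beyond the scatter). This shows a second replacement of the nitrile-bearing chain going upward, and it does so although the groups that leave and enter have the same counts of hydrogen-bond donors and acceptors and neither carries a net charge. The step has a lower bound but no exact size, since compound 1 stands at a limit of the measurement: the limit of < -3 in this assay, at which 1 of the 4 values shown sits.

The compounds shown leave open whether the rise goes with the bromine, the chain oxygen or the longer group as a whole. A chain ending in chlorine, a hydroxyl group or an amine in place of the bromine would help to separate these parts.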